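Compound 3: benzyl in place of isopropyl

The source may hold more compounds than are shown below. What is called first, only, known or untested is meant among the compounds shown, and "the series" means these compounds.

In an in vitro ADME assay on microsomes from liver (Homo sapiens) for metabolic stability, read by LC-MS, tested at 1 uM (on this read-out lower numbers stand for a shorter-lived compound and higher numbers for a longer-lived compound), compound 1 `CC(C)N/C(=N\c1nccn1C(C)C)Nc1ccc(Cl)c(Cl)c1` gives 0.375 h as a measured number. Compound 2 `CC(C)n1ccnc1/N=C(\N)Nc1ccc(Cl)c(Cl)c1` reads > 1 h and this is a limit of the assay, not a number. For the measured compounds named here, the one measured step is an at least 2.6-fold higher number from compound 1 to compound 2 (0.42 log units; beyond the scatter) for hydrogen in place of isopropyl on an amine nitrogen, and it lies beyond the scatter. Compound 3 `N/C(=N\c1nccn1Cc1ccccc1)Nc1ccc(Cl)c(Cl)c1` differs from compound 2 by benzyl in place of isopropyl on an aromatic nitrogen. Going by the values given here, the measured step sits on the amine nitrogen, so it does not measure this change, and no step on the aromatic nitrogen is available. A modest fall from compound 2 is the working expectation, and the estimated step of an at least 1.2-fold lower number from compound 2 to compound 3 (0.09 log units; that floor lies within the scatter) may stay within the scatter. Compound 3 is expected at 0.8 h in this assay, with an estimated range from 0.3 h to 2 h, and the assay may again report only a limit.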

Compound 3, half-life: > 1 h
Compound 3 gave a limit, no number; the forecaster's own chance of this, stated with the estimate: 40%; middle value at least 1.2-fold (0.09 log units) away from the limit.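

Compound 2 and compound 3 both read as limits in this assay, not as numbers, so no step between them can be read: the limit of > 1 h in this assay, at which 2 of the 3 values shown sit.

On these data alone, whether benzyl in place of isopropyl on an aromatic nitrogen changes the half-life, and in which direction, stays open.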